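The compounds below may be only part of what the source reports. "The series", "measured", "known", "first", "only" and "open" are said of these compounds alone.

Compound 1 `C=CCn1c(=O)/c(=C\c2cccc(Cl)c2)[nH]c(=O)/c1=C\c1ccccc1OC` gives 1200 nM in a functional assay on U-937 cells (Homo sapiens) for cytotoxicity, read by CCK-8 assay, with a stated time of 72 h; on this read-out lower numbers stand for stronger inhibition and higher numbers for weaker inhibition.
Compound 2 `C=CCn1c(=O)/c(=C\c2cc(Br)ccc2F)[nH]c(=O)/c1=C\c1ccccc1OC` gives 4700 nM in this assay.
Compound 3 `C=CCn1c(=O)/c(=C\c2ccccc2C(F)(F)F)[nH]c(=O)/c1=C\c1ccccc1OC` gives 1500 nM in this assay.

Compound 3 stands second highest of the three numbers in this assay. Its nearest neighbour is compound 1, since the step of a 1.3-fold higher number from compound 1 to compound 3 (0.10 log units; within the scatter) lies within the scatter, while the step of a 3.1-fold lower number from compound 2 to compound 3 (0.50 log units; beyond the scatter) is beyond it. Compound 4 `C=CCn1c(=O)/c(=C\c2cccc(C)c2)[nH]c(=O)/c1=C\c1ccccc1OC` differs from compound 3 by 3-methylphenyl in place of 2-(trifluoromethyl)phenyl on a double-bonded chain carbon bound to an aromatic carbon. Compound 1, which carries 3-chlorophenyl, is the closer comparison, and because its step of a 1.3-fold higher number from compound 1 to compound 3 (0.10 log units; within the scatter) stayed within the scatter, no large shift is foreseen. Compound 4 is therefore expected to show a 1.2-fold lower number from compound 3 to compound 4 (0.06 log units; within the scatter) in this assay, a step not beyond the scatter. The estimate for compound 4 is 1300 nM, with a range from 600 nM to 3000 nM.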

Compound 4, half-maximal inhibitory concentration: 5100 nM
Estimate against measurement, compound 4: 3.9-fold (0.59 log units) below, outside the stated range (above it).
By their numbers in this assay, from the lowest: compounds 1 and 3 (each within the scatter of the next); then compounds 2 and 4 (each within the scatter of the next).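

Methyl in place of chloro on an aromatic carbon gives a 4.3-fold higher number from compound 1 to compound 4 (0.63 log units; beyond the scatter) and is the first step here to change a single substituent while the phenyl ring stays, showing that this position responds even to so small an exchange. With a 3.4-fold higher number from compound 3 to compound 4 (0.53 log units; beyond the scatter) and a 1.1-fold higher number from compound 2 to compound 4 (0.04 log units; within the scatter) as well, compound 4 groups with compound 2 and apart from compounds 1 and 3. Nothing available explains this gap.

Still open, going by these compounds, is whether a methoxy group or an amine in place of the chloro of compound 1 would stay with compound 1 or fall with compound 4.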